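Swapping phenyl for methyl on a piperazine amide

The source may hold more compounds than are shown below. What is called first, only, known or untested is meant among the compounds shown, and "the series" means these compounds.

Measured compounds:
compound 1 `CN1CCN(C(=O)c2nc3cc(C(F)(F)F)ccc3s2)CC1` — 12.6%
compound 2 `COc1ccccc1N1CCN(C(=O)c2nc3ccccc3s2)CC1` — 53.4%
compound 3 `O=C(c1nc2ccccc2s1)N1CCN(c2ccccc2)CC1` — 67.2%

Compound 3 stands highest of the three in an ADME assay on RAW264.7 cells (Mus musculus) for cytotoxicity, read by MTT assay, with a stated time of 72 h, tested at 50 ug/mL; a lower number here means less inhibition, a higher number more inhibition at the concentration tested (going by the name of the read-out); compound 2 is nearest, and compound 1 lies furthest below. For the measured compounds named here, the single one-place comparison among the measured compounds is a number 13.8 percentage points higher from compound 2 to compound 3 (beyond the scatter), a change of a methoxy on an aromatic carbon.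

The unmeasured compound 4 `CN1CCN(C(=O)c2nc3ccccc3s2)CC1` differs from compound 3 by methyl in place of phenyl on an amine nitrogen in a ring. Going by the values given here, no measured step follows that change, and the one step known, a number 13.8 percentage points higher from compound 2 to compound 3 (beyond the scatter), does not bear on it. What the numbers do show is this: compound 4 shares its methyl on the ring nitrogen with compound 1, which differs from it only by a trifluoromethyl group, and compound 1 gives 12.6%, far below compound 3. Compound 4 is therefore expected to move by a number 45.2 percentage points lower from compound 3 to compound 4 (beyond the scatter), downward, toward the lower value. The estimate for compound 4 in this assay is 22%, in a range from 8% to 42%.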

Compound 4, a percentage reported as inhibition, at one concentration (the size of the read-out at that concentration, not a potency): 52.1%
The estimate for compound 4 lay 30.1 percentage points below the measured number, outside the stated range (above it).
By their numbers in this assay, from the lowest: compound 1; then compounds 4 and 2 (each within the scatter of the next); then compound 3.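

In this assay, the ring nitrogen proves far less sensitive than the opening comparison suggested: methyl in place of phenyl gives a number 15.1 percentage points lower from compound 3 to compound 4 (beyond the scatter), while methyl in place of 2-methoxyphenyl gives a number 1.3 percentage points lower from compound 2 to compound 4 (within the scatter), so these two groups cannot be told apart here. The large change lies instead on the aromatic carbon of the shared core, where hydrogen in place of trifluoromethyl gives a number 39.5 percentage points higher from compound 1 to compound 4 (beyond the scatter), a step well beyond either change on the nitrogen. Nothing available explains any of these steps.

The compounds shown leave open whether trifluoromethyl would have a similar effect alongside a phenyl on the ring nitrogen. They also leave open how a methoxy or an amine on that aromatic carbon, or a benzyl on the nitrogen, would read in this assay.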